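Removing the aryl from the triazole of the shared core

A few compounds are considered here, and "the series" means these few. Any claim that something is new, unique, unknown or untested is made for them only; others in the source may bear on it.

Compound 3 `CCCCCc1ccc(-c2cn(C[C@H](O)[C@H]3OC(=O)C(OCc4ccccc4)=C3OCc3ccccc3)nn2)cc1` gives the lowest number of the three measured in a functional assay on HeLa cells (Homo sapiens) for antiproliferative activity, read by MTT assay, with a stated time of 72 h (a higher number here means a weaker inhibitor, a lower number a stronger inhibitor), 8390 nM. Compound 2 `COc1ccc(-c2cn(C[C@H](O)[C@H]3OC(=O)C(OCc4ccccc4)=C3OCc3ccccc3)nn2)cc1` stands nearest with 16400 nM, and a 2.0-fold lower number from compound 2 to compound 3 (0.29 log units; within the scatter). Compound 1 `O=C1O[C@H]([C@@H](O)Cn2cc(-c3cc(F)cc(F)c3)nn2)C(OCc2ccccc2)=C1OCc1ccccc1` lies furthest with 40800 nM; here a 4.9-fold lower number from compound 1 to compound 3 (0.69 log units; beyond the scatter) and a 2.5-fold lower number from compound 1 to compound 2 (0.40 log units; beyond the scatter). Compound 4 `O=C1O[C@H]([C@@H](O)Cn2ccnn2)C(OCc2ccccc2)=C1OCc1ccccc1` differs from compound 3 by hydrogen in place of 4-pentylphenyl on an aromatic carbon. The measured steps only swap substituents on the aromatic ring that is now lost entirely, so they bear on this change only loosely; the largest of them, a 4.9-fold lower number from compound 1 to compound 3 (0.69 log units; beyond the scatter), suggests the whole group contributes. A step to a higher number, beyond the scatter, is therefore expected in this assay, estimated as a 6.0-fold higher number from compound 3 to compound 4 (0.78 log units; beyond the scatter). Compound 4 is thus estimated at 50000 nM, expected between 15000 nM and 150000 nM.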

Compound 4, half-maximal inhibitory concentration: > 100000 nM
Compound 4 ended at the assay's limit; the forecaster's own chance of this, stated with the estimate: 25%; middle value at least 2.0-fold (0.30 log units) from the limit.
By their numbers in this assay, from the lowest: compounds 3 and 2 (each within the scatter of the next); then compound 1. At a limit, above all of these: compound 4.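

Compound 4 reads only as a limit in this assay: the limit of > 100000 nM in this assay, at which 1 of the 4 values shown sits.

Whichever aryl group leaves this carbon of the five-membered aromatic ring with 3 nitrogen, the number rises: an at least 11-fold higher number from compound 3 to compound 4 (1.07 log units; beyond the scatter), an at least 6.0-fold higher number from compound 2 to compound 4 (0.78 log units; beyond the scatter) and an at least 2.4-fold higher number from compound 1 to compound 4 (0.38 log units; beyond the scatter). The earlier steps shown here only compared one substituted phenyl with another, whereas these show that the aryl group as a whole counts at this position, with 4-pentylphenyl giving the largest loss on removal.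

Going by these compounds, the full size of these steps stays open at the limit. Also open, on these data alone, is whether an unsubstituted phenyl, a bare pentyl chain or an amine on this carbon would keep the activity.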